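Fluoro for Ethyl on the Pendant Phenyl Ring

This account rests on a few compounds, and the source may have more. Where it says the series, first, only, none or still open, it means among the compounds named here.

Measured compounds:
compound 1, `Cc1cc(F)ccc1-c1cc(Cl)cc(Cl)c1/C=C/[C@@H]1C[C@@H](O)CC(=O)O1` — 36 nM
compound 2, `O=C1C[C@H](O)C[C@@H](/C=C/c2c(Cl)cc(Cl)cc2CCc2ccccc2)O1` — 430 nM
compound 3, `CCc1cccc(-c2cc(Cl)cc(Cl)c2/C=C/[C@@H]2C[C@@H](O)CC(=O)O2)c1` — 44 nM

In an assay for inhibition of 3-hydroxy-3-methylglutaryl-coenzyme A reductase (Rattus norvegicus) (on this read-out higher numbers stand for weaker inhibition and lower numbers for stronger inhibition), compound 3 gives 44 nM. Its distance from compound 1 is small, a 1.2-fold higher number from compound 1 to compound 3 (0.09 log units; within the scatter), whereas compound 2 stands well apart from both, a 9.8-fold lower number from compound 2 to compound 3 (0.99 log units; beyond the scatter) and a 12-fold higher number from compound 1 to compound 2 (1.08 log units; beyond the scatter). The large steps therefore belong to the exchange of a directly attached phenyl for a phenethyl chain, while the exchange of one substituted phenyl for another leaves the number where it was.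

Compound 4, `O=C1C[C@H](O)C[C@@H](/C=C/c2c(Cl)cc(Cl)cc2-c2cccc(F)c2)O1`, keeps the directly attached phenyl and differs from compound 3 only by fluoro in place of ethyl on an aromatic carbon. Among the compounds with values here, no measured step changes a single substituent on that ring alone; the nearest precedent is the step from compound 1 to compound 3, which swaps one pattern of small substituents for another and stays within the scatter, a 1.2-fold higher number from compound 1 to compound 3 (0.09 log units; within the scatter). The steps through compound 2 do not bear on compound 4, since the phenyl stays in place.

On that basis compound 4 is expected to show a step of a 1.1-fold higher number from compound 3 to compound 4 (0.06 log units; within the scatter), no larger than the scatter, giving an estimate of 50 nM, within 20 nM to 130 nM.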

Compound 4, half-maximal inhibitory concentration: 70 nM
The estimate for compound 4 lay 1.4-fold (0.15 log units) below the measured number, and the stated range covers the measured number.
By their numbers in this assay, from the lowest: compounds 1, 3 and 4 (each within the scatter of the next); then compound 2.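

In this assay, within the data shown here, the exchange of ethyl for fluoro, on an aromatic carbon meta to a large group, is the first change of one substituent alone on the pendant ring, and it stays within the scatter, with a 1.6-fold higher number from compound 3 to compound 4 (0.20 log units; within the scatter) as the step. Two carbon atoms leave and one fluorine enters at this position without a step beyond the scatter, and the comparison with a differently substituted phenyl also stays within it, at a 1.9-fold higher number from compound 1 to compound 4 (0.29 log units; within the scatter) as the step. The gap to the phenethyl compound remains beyond the scatter with a single fluoro on the phenyl, at a 6.1-fold lower number from compound 2 to compound 4 (0.79 log units; beyond the scatter) as the step, so that gap does not depend on the ethyl group or on the substituents of the 4-fluoro-2-methylphenyl. Nothing available explains why these numbers fall as they do. Going by these compounds, it remains open whether an amine, a carboxylic acid or a longer chain on this carbon would leave the number within the scatter, and whether fluoro for ethyl would behave the same way on another carbon of the ring.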